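A few compounds are considered here, and "the series" means these few. Any claim that something is new, unique, unknown or untested is made for them only; others in the source may bear on it.

In an ADME assay on HFF cells (Homo sapiens) for cytotoxicity, read by MTT assay, with a stated time of 72 h (on this read-out lower numbers stand for stronger inhibition and higher numbers for weaker inhibition), compound 2 `O=C1O[C@H]([C@@H](O)Cn2cc(CNS(=O)(=O)c3ccc(Cl)cc3)nn2)C(OCc2ccccc2)=C1OCc1ccccc1` gives 20 nM. Compound 1 `CCCCCc1ccc(-c2cn(C[C@H](O)[C@H]3OC(=O)C(OCc4ccccc4)=C3OCc3ccccc3)nn2)cc1` gives > 100000 nM, which is a limit of the assay and not a number (the limit of > 100000 nM in this assay, at which 1 of the 2 values shown sits). Compound 2 therefore holds the only actual number shown, and the one measured step, an at least 5000-fold lower number from compound 1 to compound 2 (3.69 log units; beyond the scatter), arises from swapping a whole group rather than adding a small one. Compound 3 `O=C1O[C@H]([C@@H](O)Cn2cc(CNS(=O)(=O)c3ccc(Cl)cc3F)nn2)C(OCc2ccccc2)=C1OCc1ccccc1` differs from compound 2 by fluoro in place of hydrogen on an aromatic carbon, placed on an aromatic carbon of a six-membered aromatic ring of carbon only, ortho to a large group and meta to a chloro group. For the measured compounds named here, no measured step here adds a fluoro to such a ring, so the large measured step gives no guide to this particular change. The expectation is therefore a step no larger than the scatter, no change at the digits printed from compound 2 to compound 3 (within the scatter), and compound 3 is estimated at 20 nM, within the range 8 nM to 50 nM.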

Compound 3, half-maximal inhibitory concentration: 20 nM
For compound 3 middle estimate and measured number coincide at the digits printed; low and high end bracket the measured number.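

Changing 4-chlorophenyl to 4-chloro-2-fluorophenyl, which places a fluoro ortho to a large group and meta to a chloro group, gives no change at the digits printed from compound 2 to compound 3 (within the scatter) in this assay. At this position, then, one added fluorine atom leaves the cytotoxicity reading where it was, whereas the earlier step replaced a whole group and could only be read against a limit. That earlier step began from compound 1, whose value is a limit and not a number: the limit of > 100000 nM in this assay, at which 1 of the 3 values shown sits.

The compounds shown leave open whether a larger group at the same place, such as methoxy or trifluoromethyl, would move the number. They also leave open whether a fluoro on another carbon of this ring would behave in the same way.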